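The compounds below may be only part of what the source reports. "The series", "measured", "known", "first", "only" and "open" are said of these compounds alone.

In a functional assay on the whole organism (strain Wistar) for inhibition, with Rattus norvegicus as the target, read by paw edema, with a stated time of 1 h, at a dose of 100 mg/kg (on this read-out higher numbers stand for more inhibition at the one dose given (going by the name of the read-out) and lower numbers for less inhibition), compound 2 `COc1cc2c(cc1OC)C(CC(=O)Nc1ccc(Cl)cc1)CC2` gives 71.9%, the highest of the three measured numbers. Compound 1 `COc1cc2c(cc1OC)C(CC(=O)Nc1cccc(Cl)c1)CC2` gives 31.3% and compound 3 `COc1cc2c(cc1OC)C(CC(=O)Nc1ccc(C)cc1)CC2` gives 34.4%. The unmeasured compound 4 `COc1cc2c(cc1OC)C(CC(=O)Nc1cccnc1)CC2` differs from compound 2 by a single change, (pyridin-3-yl in place of 4-chlorophenyl on an amide-type nitrogen). Within the data shown here, two measured steps bear on this: a number 37.5 percentage points lower from compound 2 to compound 3 (beyond the scatter), and a number 40.6 percentage points higher from compound 1 to compound 2 (beyond the scatter). Both show that the 4-chlorophenyl group goes with far higher inhibition than the alternatives tried, and in compound 4 that group is gone. Among the measured compounds shown here, no measured compound carries a pyridin-3-yl group, so its own contribution is unknown. Compound 4 is therefore expected to give 35%, within a range of 18% to 55%. The step from compound 2 to compound 4 is expected to be a number 36.9 percentage points lower from compound 2 to compound 4 (beyond the scatter), a fall beyond the scatter.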

Compound 4, a percentage reported as inhibition, in the whole organism at one dose (the size of the read-out at that dose, not a potency): 25%
The estimate for compound 4 lay 10 percentage points above the measured number, and the stated range covers the measured number.
By their numbers in this assay, from the lowest: compounds 4, 1 and 3 (each within the scatter of the next); then compound 2.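

Pyridin-3-yl on the amide-type nitrogen brings a number 46.9 percentage points lower from compound 2 to compound 4 (beyond the scatter), so this aromatic ring with a hetero atom does not keep the high number seen with 4-chlorophenyl. Among these compounds, the step of a number 9.4 percentage points lower from compound 3 to compound 4 (within the scatter) and the step of a number 6.3 percentage points lower from compound 1 to compound 4 (within the scatter) both stay small, leaving 4-chlorophenyl as the only one of the four groups that stands apart from the rest. Nothing available here explains this large fall. Still open, as far as these compounds go, is whether 4-fluorophenyl or 4-bromophenyl would keep the high number, and how a saturated cyclohexyl ring would compare.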